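Replacing the 1,2-dihydroxy-1-(trifluoromethyl)ethyl group of compound 2

A few compounds are considered here, and "the series" means these few. Any claim that something is new, unique, unknown or untested is made for them only; others in the source may bear on it.

In an ADME assay (liver) for metabolic stability, with Liver microsome (Rattus norvegicus) as the target, using microsomes and NADPH, with a stated time of 30 min (on this read-out lower numbers stand for slow clearance and higher numbers for fast clearance), compound 1 `CC#C[C@H]1CN(S(=O)(=O)c2ccc(N)nc2)CCN1c1ccc(S(=N)(=O)C2CC2)cc1` gives 23 mL.min-1.g-1. Compound 2 `CC#C[C@H]1CN(S(=O)(=O)c2ccc(N)nc2)CCN1c1ccc([C@](O)(CO)C(F)(F)F)cc1` gives < 14 mL.min-1.g-1, which is a limit of the assay and not a number, so compound 2 stands at the limit of < 14 mL.min-1.g-1 in this assay, at which 1 of the 2 values shown sits. Compound 3 `CC#C[C@H]1CN(S(=O)(=O)c2ccc(N)nc2)CCN1c1ccc([S+](C)[O-])cc1` differs from compound 2 as follows: a group of 3 heavy atoms (1 carbon, 1 oxygen, 1 sulfur; no ring) in place of a group of 8 heavy atoms (3 carbon, 2 oxygen, 3 fluorine; no ring), on an aromatic carbon. Among the measured compounds shown here, the one measured step that bears on this is an at least 1.6-fold lower number from compound 1 to compound 2 (0.21 log units; that floor lies within the scatter), also a change on an aromatic carbon, and its floor lies within the scatter. For the measured compounds named here, with only that step as a guide, a small move to a higher number is expected, an at least 1.5-fold higher number from compound 2 to compound 3 (0.19 log units; that floor lies within the scatter). Compound 3 is estimated at 22 mL.min-1.g-1, with an expected range from 10 mL.min-1.g-1 to 48 mL.min-1.g-1.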

Compound 3, intrinsic clearance in microsomes: 17 mL.min-1.g-1
The estimate for compound 3 lay 1.3-fold (0.11 log units) above the measured number; measured number inside the range.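

Even the much smaller group of compound 3, on this aromatic carbon, gives only an at least 1.2-fold higher number from compound 2 to compound 3 (0.08 log units; that floor lies within the scatter), and a 1.4-fold lower number from compound 1 to compound 3 (0.13 log units; within the scatter). Across the three groups seen at this position, then, this assay shows no step beyond the scatter, although the group size varies widely. The value of compound 2 is a limit of the assay and not a number: the limit of < 14 mL.min-1.g-1 in this assay, at which 1 of the 3 values shown sits.

The compounds shown leave open where compound 2 actually lies. They also leave open whether an amine or a carboxylic acid on this aromatic carbon would produce a step beyond the scatter.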